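This account rests on a few compounds, and the source may have more. Where it says the series, first, only, none or still open, it means among the compounds named here.

In an ADME assay on MT4 cells (Homo sapiens) for cytotoxicity, read by MTT assay (on this read-out lower numbers stand for higher toxicity in this test and higher numbers for lower toxicity in this test), compound 1 `CCc1c(Cc2c(F)cccc2Cl)nc(SCC(=O)c2ccc(F)cc2)[nH]c1=O` and compound 2 `CC(C)c1c(Cc2c(F)cccc2Cl)nc(SCC(=O)c2ccc(F)cc2)[nH]c1=O` share one core and differ only in the chain attached to it. Compound 1 gives > 57000 nM, which is a limit of the assay and not a number. Compound 2 gives > 56000 nM, which is likewise a limit. Compound 2 therefore stands only at a limit, and no measured number fixes its place.

Compound 3 `CCC(C)c1c(Cc2c(F)cccc2Cl)nc(SCC(=O)c2ccc(F)cc2)[nH]c1=O` extends that chain: methyl in place of hydrogen on a saturated chain carbon, two bonds along the chain from an aromatic carbon. The methyl replaces a hydrogen on a saturated chain carbon, two bonds along the chain from an aromatic carbon, turning isopropyl into sec-butyl.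

For the measured compounds named here, the only measured step that bears on this change is a step that the two limits leave unreadable from compound 1 to compound 2, which also puts methyl in place of hydrogen on a saturated chain carbon. It offers no size to carry over, so no step beyond the scatter is expected in this assay, in either direction, and another limit is the likeliest report. The estimated step is an at least 1.0-fold lower number from compound 2 to compound 3 (0.01 log units; that floor lies within the scatter). The expected value for compound 3 is 54000 nM, with an estimated range from 25000 nM to 80000 nM.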

Compound 3, half-maximal cytotoxic concentration: > 54000 nM
Compound 3: only a limit was reported (the forecaster's own chance of this, stated with the estimate: 75%); the middle value sits exactly at the limit.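

Compound 3 gives > 54000 nM in this assay, which is a limit of the assay and not a number. For the compounds shown here, compound 1 and compound 2 also stand only at limits, so no step among the three compounds can be read. The compounds shown leave open where any of the three actually lies, and whether changing the chain moves the read-out at all.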